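A few compounds are considered here, and "the series" means these few. Any claim that something is new, unique, unknown or untested is made for them only; others in the source may bear on it.

Compound 1 `O=C(O)c1cc(C2N=NN=N2)ccc1O`: 110 mg/kg
Compound 2 `O=C(O)c1cc(-n2cncn2)ccc1O`: 200 mg/kg

Both compounds were tested in a functional assay on the whole organism for inhibition, with Rattus norvegicus as the target, read by paw edema; a lower number here means that less compound is needed, a higher number that more compound is needed for the effect. Among the measured compounds shown here, only two numbers are available, and the single measured step between them, a 1.8-fold higher number from compound 1 to compound 2 (0.26 log units; within the scatter), falls within the scatter, so compound 2 cannot be set apart from compound 1 on the evidence at hand.

Compound 3 `O=C(O)c1cc(-c2ncc[nH]2)ccc1O` is the next compound in this series. It differs from compound 2 by 1H-imidazol-2-yl in place of 1H-1,2,4-triazol-1-yl on an aromatic carbon. For the measured compounds named here, the one measured step that bears on this change is the step from compound 1 to compound 2, which also exchanged one five-membered ring carrying heteroatoms for another at the same aromatic carbon of the shared core; that exchange, a 1.8-fold higher number from compound 1 to compound 2 (0.26 log units; within the scatter), produced no movement beyond the scatter. With nothing else to go on, a similar ring exchange at the same place is expected to leave the number where it is, and the expected step of a 1.1-fold lower number from compound 2 to compound 3 (0.02 log units; within the scatter) is therefore one that stays inside the scatter. Compound 3 is accordingly estimated at 190 mg/kg in this assay, with a range from 80 mg/kg to 450 mg/kg.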

Compound 3, dose for half-maximal effect: 200 mg/kg
Estimate against measurement, compound 3: 1.1-fold (0.02 log units) below; low and high end bracket the measured number.
By their numbers in this assay, from the lowest: compounds 1, 2 and 3 (each within the scatter of the next).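

In this assay, the place on an aromatic carbon meta to a carboxy group and para to a hydroxy group now carries a second exchange, and 1H-imidazol-2-yl in place of 1H-1,2,4-triazol-1-yl gives no change at the digits printed from compound 2 to compound 3 (within the scatter). The two groups differ in their hetero atoms and in their counts of hydrogen-bond donors and acceptors, yet these differences go with no step beyond the scatter in this whole-animal read-out. The comparison with the five-membered non-aromatic ring of compound 1 gives a 1.8-fold higher number from compound 1 to compound 3 (0.26 log units; within the scatter), so the three five-membered rings shown at this place cannot be told apart in this assay, and none can be ranked above another. Nothing on hand accounts for this flat result or tests it by a separate measurement.

What the compounds shown leave open is whether a group of another kind at this place, such as an amine, a phenyl ring or a longer alkyl chain, would move the number beyond the scatter. They also leave open how the number would respond if the carboxy group gave way to a methyl ester or the hydroxy group to a methoxy group.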